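Shortening the chain between core and methylpiperazine

The compounds below may be only part of what the source reports. "The series", "measured", "known", "first", "only" and "open" are said of these compounds alone.

Compound 1 `CN1CCN(CCCCCn2c3c(c4ccccc42)C(=O)c2c[n+]([O-])c4ccccc4c2C3=O)CC1` gives 870 nM in a functional assay on A549 cells (Homo sapiens) for cytotoxicity, read by MTT assay, with a stated time of 72 h (a higher number here means a weaker inhibitor, a lower number a stronger inhibitor), the highest of the three numbers in hand. Compound 2 `CN1CCN(CCCn2c3c(c4ccccc42)C(=O)c2c[n+]([O-])c4ccccc4c2C3=O)CC1` gives 140 nM in this assay, and compound 3 `CN(C)CCCCCn1c2c(c3ccccc31)C(=O)c1c[n+]([O-])c3ccccc3c1C2=O` gives 210 nM. Both a 6.2-fold lower number from compound 1 to compound 2 (0.79 log units; beyond the scatter) and a 4.1-fold lower number from compound 1 to compound 3 (0.62 log units; beyond the scatter) lead away from compound 1, whereas a 1.5-fold higher number from compound 2 to compound 3 (0.18 log units; within the scatter) leaves compounds 2 and 3 within the scatter of each other. Compound 4 `CN1CCN(CCCCn2c3c(c4ccccc42)C(=O)c2c[n+]([O-])c4ccccc4c2C3=O)CC1` differs from compound 1 by 4-methylpiperazin-1-yl in place of (4-methylpiperazin-1-yl)methyl on a saturated chain carbon, four bonds along the chain from an aromatic nitrogen. This is the same direction of change as in the step of a 6.2-fold lower number from compound 1 to compound 2 (0.79 log units; beyond the scatter), only carried less far, so compound 4 is intermediate in chain length relative to compound 1 and compound 2. A lower number than that of compound 1 is therefore expected for compound 4, most likely of a size smaller than a 6.2-fold lower number from compound 1 to compound 2 (0.79 log units; beyond the scatter) but beyond the scatter. Compound 4 is expected to give 300 nM in this assay, with a range from 120 nM to 750 nM, which amounts to a 2.9-fold lower number from compound 1 to compound 4 (0.46 log units; beyond the scatter).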

Compound 4, half-maximal inhibitory concentration: 90 nM
Compound 4: the middle estimate sits 3.3-fold (0.52 log units) above what was measured; the whole stated range lies above it.
By their numbers in this assay, from the lowest: compounds 4, 2 and 3 (each within the scatter of the next, the first and the last beyond it); then compound 1.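

In this assay, the 4-methylpiperazin-1-yl chain does not respond to length in a gradual way: a 9.7-fold lower number from compound 1 to compound 4 (0.99 log units; beyond the scatter) shows that losing a single chain carbon from compound 1 is already enough for a large drop, while a 1.6-fold lower number from compound 2 to compound 4 (0.19 log units; within the scatter) leaves the two shorter chains indistinguishable. Compound 4 also separates from the dimethylamino compound, with a 2.3-fold lower number from compound 3 to compound 4 (0.37 log units; beyond the scatter), whereas compound 2 could not be told apart from it. Nothing measured here offers a reason for this behaviour at the position.

The compounds shown leave open whether a 2-(4-methylpiperazin-1-yl)ethyl group on the aromatic nitrogen would hold the lower numbers or lose them. They also leave open whether a morpholine or piperidine, or a dimethylamino group on the shorter chains, would follow the same course.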